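The source may report more compounds than this note shows. Statements on the series, on what has been measured and on what is new or still open speak of the compounds shown alone.

Measured compounds:
Compound 1 `COc1cc2nc(N3CCC(OCCOC(C)C)CC3)nc(N)c2cc1OC` gives 0.67 nM in an assay on brain for displacement of a labelled ligand from Adrenergic receptor alpha-1 (Rattus norvegicus); a lower number here means a stronger inhibitor, a higher number a weaker inhibitor.
Compound 2 `COc1cc2nc(N3CCC(OCCO)CC3)nc(N)c2cc1OC` gives 2.2 nM in this assay.
Compound 3 `CCOC(C)COC1CCN(c2nc(N)c3cc(OC)c(OC)cc3n2)CC1` gives 0.99 nM in this assay.

Among these three numbers compound 3 stands second highest: its nearest neighbour is compound 1, at a 1.5-fold higher number from compound 1 to compound 3 (0.17 log units; within the scatter), a gap within the scatter, while compound 2 lies further away, at a 2.2-fold lower number from compound 2 to compound 3 (0.35 log units; beyond the scatter). Compound 4 `CCOCC(OC1CCN(c2nc(N)c3cc(OC)c(OC)cc3n2)CC1)c1ccccc1` is not yet measured. It differs from compound 3 in one place: 2-ethoxy-1-phenylethyl in place of 2-ethoxypropyl on an oxygen on a saturated carbon. For the measured compounds named here, no measured step changes this part of the chain in the same way. The steps that touch the same chain are a 1.5-fold higher number from compound 1 to compound 3 (0.17 log units; within the scatter), which stays within the scatter, and a 2.2-fold lower number from compound 2 to compound 3 (0.35 log units; beyond the scatter), a modest step, while a 3.3-fold higher number from compound 1 to compound 2 (0.52 log units; beyond the scatter) concerns an oxygen bearing hydrogen rather than isopropyl. These steps show the chain accepting several end groups with shifts that stay modest at most, so the expected step in this assay is a 1.5-fold higher number from compound 3 to compound 4 (0.18 log units; within the scatter), one that should not go beyond the scatter in either direction. Compound 4 is therefore estimated at 1.5 nM, with a range of 0.5 nM to 5 nM.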

Compound 4, inhibition constant: 10 nM
Beside the measured number, compound 4's estimate is 6.7-fold (0.82 log units) below it; the whole stated range lies below it.
By their numbers in this assay, from the lowest: compounds 1 and 3 (each within the scatter of the next); then compound 2; then compound 4.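

In this assay the chains shown earlier on this oxygen all gave similar numbers, but 2-ethoxy-1-phenylethyl, the only group here with a six-membered aromatic ring, brings a 10-fold higher number from compound 3 to compound 4 (1.00 log units; beyond the scatter) as the change from 2-ethoxypropyl. The same holds against the other two chains, with a 4.5-fold higher number from compound 2 to compound 4 (0.66 log units; beyond the scatter) for 2-hydroxyethyl and a 15-fold higher number from compound 1 to compound 4 (1.17 log units; beyond the scatter) for 2-isopropoxyethyl, so this position does not accept every chain equally and all three chains without the ring give lower numbers. Nothing available explains why the ring has this effect.

The compounds shown cannot tell whether the loss belongs to the aromatic ring itself or to any larger group there, which a methyl or a cyclohexyl in place of the phenyl would separate. They also leave open how a chain ending in an amine or a carboxylic acid would behave at this oxygen.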